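This account rests on a few compounds, and the source may have more. Where it says the series, first, only, none or still open, it means among the compounds named here.

Measured compounds in an assay for binding affinity to dual specificity mitogen-activated protein kinase kinase 4 (Homo sapiens), read by KINOMEscan, tested at 100 nM; on this read-out lower numbers stand for a stronger effect and higher numbers for a weaker effect at the one concentration tested:
Compound 1, `CCCS(=O)(=O)Nc1ccc(F)c(C(=O)c2n[nH]c3ncc(-c4cccc(Cl)c4)cc23)c1F`, for which compound 1 gives 40%.
Compound 2, `CCCS(=O)(=O)Nc1ccc(F)c(C(=O)c2n[nH]c3ncc(-c4ccccc4F)cc23)c1F`, for which compound 2 gives 2%.
Compound 3, `CCCS(=O)(=O)Nc1ccc(F)c(C(=O)c2n[nH]c3ncc(-c4ccccc4OC)cc23)c1F`, for which compound 3 gives 1.9%.

Compound 3 stands at the lowest number of the three, but compound 2 sits so close that the two cannot be told apart, as the step of a number 0.1 percentage points lower from compound 2 to compound 3 (within the scatter) shows. The gap to compound 1 is large: a number 38.1 percentage points lower from compound 1 to compound 3 (beyond the scatter), and the matching step a number 38 percentage points lower from compound 1 to compound 2 (beyond the scatter) is of the same size. Both large steps replace 3-chlorophenyl with a group substituted at its second position.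

Compound 4, `CCCS(=O)(=O)Nc1ccc(F)c(C(=O)c2n[nH]c3ncc(-c4cccc(OC)c4)cc23)c1F`, differs from compound 3 only in one way: 3-methoxyphenyl in place of 2-methoxyphenyl on an aromatic carbon. This change keeps the methoxy group but moves it into the pattern of substitution seen in compound 1, the compound with the highest number. For the measured compounds named here, no measured step swaps methoxy between these two positions, so the direction rests on compound 1 alone, and methoxy is not chloro. A rise in this assay towards compound 1 is therefore expected, though a smaller one: the expected step is a number 18.1 percentage points higher from compound 3 to compound 4 (beyond the scatter). Compound 4 is estimated at 20%, with a range from 3% to 45%.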

Compound 4, a percentage reported as activity, at one concentration (the size of the read-out at that concentration, not a potency): 6.3%
Compound 4: the middle estimate sits 13.7 percentage points above what was measured; measured number inside the range.
By their numbers in this assay, from the lowest: compounds 3, 2 and 4 (each within the scatter of the next); then compound 1.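

In this assay, exchanging 2-methoxyphenyl for 3-methoxyphenyl makes no difference that can be read (a number 4.4 percentage points higher from compound 3 to compound 4 (within the scatter)), and the comparison with the 2-fluorophenyl compound also stays within the scatter (a number 4.3 percentage points higher from compound 2 to compound 4 (within the scatter)), so a substituent in the pattern of 3-methoxyphenyl does not by itself bring a high number at this place on the shared core. The large change appears instead when the pattern stays fixed and only the substituent differs, with methoxy in place of chloro (a number 33.7 percentage points lower from compound 1 to compound 4 (beyond the scatter)), and this makes compound 4 an exception to the earlier impression that the two large steps followed from the pattern of substitution. Nothing available here explains why chloro and methoxy part so widely at this place.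

Still open, as far as these compounds go, is whether the high number of compound 1 belongs to chloro in particular, which 2-chlorophenyl and 3-fluorophenyl would help to separate from the pattern of substitution. Also open, from the compounds shown here alone, is how this place on the core would respond to an amine or a carboxylic acid on the phenyl ring.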